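Changing the aryl group: from compound 3 to compound 4

The source may hold more compounds than are shown below. What is called first, only, known or untested is meant among the compounds shown, and "the series" means these compounds.

Compound 1 `Cc1cccc(CNc2ncnc3c2ncn3[C@@H]2O[C@H](CO)[C@@H](O)[C@H]2O)c1`: in a functional assay on HOS cells (Homo sapiens) for antiproliferative activity, with a stated time of 72 h (a lower number here means a stronger inhibitor, a higher number a weaker inhibitor), compound 1 gives only a limit, > 166000 nM.
Compound 2 `OC[C@H]1O[C@@H](n2cnc3c(NCc4ccc(Cl)cc4Cl)ncnc32)[C@H](O)[C@@H]1O`: in this assay compound 2 likewise gives only a limit, > 166000 nM.
Compound 3 `COc1cc(CNc2ncnc3c2ncn3[C@@H]2O[C@H](CO)[C@@H](O)[C@H]2O)cc(OC)c1`: in this assay compound 3 gives "not determined" (no result reported).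

Compound 3 thus has no place on the numbers shown: of the three entries in this assay, two are limits and its own is blank. Within the data shown here, the single step between measured compounds, a step that the two limits leave unreadable from compound 1 to compound 2, cannot be read because both of its ends rest on (the limit of > 166000 nM in this assay, at which 2 of the 3 values shown sit). In other words, neither measured compound showed any inhibition within the range the assay can report.

Compound 4 `COc1cccc(CNc2ncnc3c2ncn3[C@@H]2O[C@H](CO)[C@@H](O)[C@H]2O)c1O` is the next compound to be tested. It differs from compound 3 by 2-hydroxy-3-methoxyphenyl in place of 3,5-dimethoxyphenyl on a saturated chain carbon bound to a nitrogen on an aromatic ring. Among the measured compounds shown here, no measured step bears on this change, and the one step that exists is unreadable, so there is no basis for expecting a move in this assay in either direction. With both measured neighbours sitting at the limit, the most likely outcome for compound 4 is again a value at or near that limit, and it is expected to come out at about 200000 nM, somewhere between 50000 nM and 1000000 nM, quite possibly reported only as a limit rather than a number.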

Compound 4, half-maximal inhibitory concentration: > 166000 nM
Compound 4 ended at the assay's limit; the forecaster's own chance of this, stated with the estimate: 75%; the middle value does not contradict the limit.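

The steps to compound 4 from compound 1 and from compound 2 cannot be read, because all three compounds rest on the same limit rather than on numbers: the limit of > 166000 nM in this assay, at which 3 of the 4 values shown sit.

The compounds shown leave open whether any aryl group on the shared core gives a measurable value in this assay and so whether 2-hydroxy-3-methoxyphenyl differs at all from 3-methylphenyl or 2,4-dichlorophenyl.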